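The source may report more compounds than this note shows. Statements on the series, on what has been measured and on what is new or still open speak of the compounds shown alone.

Compound 1 `CCNc1nnc(Cn2c(=O)oc3ccc(C)cc32)s1` was tested in a functional assay on the whole organism with Mus musculus as the target, read by paw edema, with a stated time of 360 min, at a dose of 50 mg/kg by the oral route (on this read-out higher numbers stand for a weaker effect at the one dose given and lower numbers for a stronger effect), where compound 1 gives 94%, the lowest of the three numbers recorded. Compound 3 `CCNC(=S)NNC(=O)Cn1c(=O)oc2ccc(C)cc21` gives 128% in this assay, and compound 2 `CCCNC(=S)NNC(=O)Cn1c(=O)oc2ccc(C)cc21` gives 177%. The difference between the core of compound 1 and the core of compound 3 is not broken down here. From compound 3 to compound 2 the change is methyl in place of hydrogen on a saturated chain carbon, two bonds along the chain from an amide-type nitrogen, and it brought a number 49 percentage points higher from compound 3 to compound 2 (beyond the scatter). Compound 4 `CCCNc1nnc(Cn2c(=O)oc3ccc(C)cc32)s1` has not yet been measured in this assay; from compound 1 to compound 4 the change is methyl in place of hydrogen on a saturated chain carbon, two bonds along the chain from a nitrogen on an aromatic ring. This is the same kind of change, but the saturated chain carbon lies two bonds along the chain from a nitrogen on an aromatic ring rather than from an amide-type nitrogen. Because the earlier step was a number 49 percentage points higher from compound 3 to compound 2 (beyond the scatter), compound 4 is estimated to show a number 31 percentage points higher from compound 1 to compound 4 (beyond the scatter), a step in the same direction and somewhat smaller. Compound 4 is therefore estimated at 125%, between 95% and 165%.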

Compound 4, a percentage reported as activity, at one dose (the size of the read-out at that dose, not a potency): 110%
Estimate against measurement, compound 4: 15 percentage points above; the range from low to high includes it.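

In this assay the change from ethylamino to propylamino brought a number 16 percentage points higher from compound 1 to compound 4 (beyond the scatter). The direction of the change carried over from one core to the other, but its size did not: the same change on two cores in this assay, a number 49 percentage points higher (beyond the scatter) from compound 3 to compound 2 and a number 16 percentage points higher (beyond the scatter) from compound 1 to compound 4, 33 percentage points apart, beyond the scatter of two such steps This rests on a single pair on each core, so it does not show why the two steps differ or how the same change would behave on a further core.

The compounds shown leave open what a longer chain such as butylamino, or a branched one such as isopropylamino, would give on either core. They also leave open whether the number would keep rising as the chain grows.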